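A few compounds are considered here, and "the series" means these few. Any claim that something is new, unique, unknown or untested is made for them only; others in the source may bear on it.

Compound 1 `CC(=O)OC1CCC(CN2CCN(c3cc(=O)c4cc(C(F)(F)F)cc([N+](=O)[O-])c4s3)CC2)CC1` was tested in an ADME assay on cells (Hepatocyte, Mus musculus) for metabolic stability, with a stated time of 30 min (on this read-out lower numbers stand for a less stable compound and higher numbers for a more stable compound), where compound 1 gives 0%. Compound 2 `Nc1cc(C(F)(F)F)cc2c(=O)cc(N3CCN(CC4CCC(O)CC4)CC3)sc12` gives 60%, a number higher beyond the scatter, so compound 1 stands lowest of the two numbers in this assay. Compound 3 `O=C(OC1CCC(CN2CCN(c3cc(=O)c4cc(C(F)(F)F)cc([N+](=O)[O-])c4s3)CC2)CC1)c1cccs1` has not yet been measured. It differs from compound 1 in one place (thiophen-2-yl in place of methyl on a carbonyl carbon); cut one bond further out, the change reads acetoxy to ((thiophen-2-yl)carbonyl)oxy. Among the measured compounds shown here, no step between measured compounds covers this change. Compound 3 is expected to stay low, with the expected step of a number 5 percentage points higher from compound 1 to compound 3 (within the scatter) not beyond the scatter. Compound 3 is estimated at 5%, within 0% to 25%.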

Compound 3, percent of the compound remaining: 1.8%
Compound 3: middle estimate off by 3.2 percentage points, on the high side; the measured number falls inside the stated range.
By their numbers in this assay, from the lowest: compounds 1 and 3 (each within the scatter of the next); then compound 2.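

In this assay, thiophen-2-yl in place of methyl on this carbonyl carbon gives a number 1.8 percentage points higher from compound 1 to compound 3 (within the scatter), so the enlarged group, with its one five-membered aromatic ring, does not separate the two compounds on this read-out. Nothing measured here bears on why these two numbers lie so close. Compound 2 differs from compound 1 in more than one place, which leaves open which difference goes with its number. Also open, as far as these compounds go, is whether a phenyl ring or a longer chain on this carbonyl carbon would read any differently.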